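This account rests on a few compounds, and the source may have more. Where it says the series, first, only, none or still open, it means among the compounds named here.

Of the compounds shown here, three sharing one core have been measured in an assay on Prostate gland for inhibition of steroid 5-alpha-reductase (Rattus norvegicus); on this read-out lower numbers stand for stronger inhibition and higher numbers for weaker inhibition. Compound 1 `CCCC(C)n1ccc2cc(/C(C)=C/C(=O)Nc3ccccc3OCCCC(=O)O)ccc21` gives 7.8 nM. Compound 2 `CCCCCC(CCCCC)n1ccc2cc(/C(C)=C/C(=O)Nc3ccccc3OCCCC(=O)O)ccc21`, which carries a 1-pentylhexyl on the aromatic nitrogen, gives 25 nM, and the exchange reads a 3.2-fold higher number from compound 1 to compound 2 (0.51 log units; beyond the scatter). Compound 3 `C/C(=C\C(=O)Nc1ccccc1OCCCC(=O)O)c1ccc2c(ccn2Cc2ccc(F)cc2)c1`, with a 4-fluorobenzyl on that nitrogen, gives 97 nM, the highest number of the three: a 12-fold higher number from compound 1 to compound 3 (1.09 log units; beyond the scatter) and a 3.9-fold higher number from compound 2 to compound 3 (0.59 log units; beyond the scatter). Compound 4 `C/C(=C\C(=O)Nc1ccccc1OCCCC(=O)O)c1ccc2c(ccn2Cc2ccc(C(C)(C)C)cc2)c1` has not yet been measured. It differs from compound 3 in one place, (tert-butyl in place of fluoro on an aromatic carbon). Going by the values given here, no measured step touches the 4-fluorobenzyl itself; the steps that exist exchange the whole group on the aromatic nitrogen, and they show that compound 3, the benzyl-bearing one, sits well apart from the two alkyl-bearing compounds. The exchange from compound 3 to compound 4 is a smaller structural move than any of those steps, and nothing in the data shows its direction. A step of no more than modest size, in either direction, is therefore expected in this assay, with a move toward a higher number thought slightly more likely. Compound 4 is estimated at 150 nM, with a range from 50 nM to 500 nM, which would mean a 1.5-fold higher number from compound 3 to compound 4 (0.19 log units; within the scatter).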

Compound 4, half-maximal inhibitory concentration: 170 nM
Beside the measured number, compound 4's estimate is 1.1-fold (0.05 log units) below it, within the range that was stated.
By their numbers in this assay, from the lowest: compound 1; then compound 2; then compounds 3 and 4 (each within the scatter of the next).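

In this assay, going by these compounds alone, the exchange of tert-butyl for fluoro, on an aromatic carbon para to a large group, reads a 1.8-fold higher number from compound 3 to compound 4 (0.24 log units; within the scatter) and so is the first look at a change inside the benzyl group itself: 4 heavy atoms in place of 1 at this place give no difference that can be told from the scatter. The separation of the benzyl-bearing compounds from the alkyl-bearing ones also holds for this second benzyl group, with a 6.8-fold higher number from compound 2 to compound 4 (0.83 log units; beyond the scatter) and with a 22-fold higher number from compound 1 to compound 4 (1.34 log units; beyond the scatter) as the two steps on the aromatic nitrogen. Nothing available bears on the reason for this result.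

The compounds shown leave open whether an amine, a hydroxyl or a carboxylic acid at this place would stay within the scatter of fluoro and tert-butyl, and where the plain benzyl, with hydrogen at this place, would fall. They also leave open whether a phenylethyl or a longer chain carrying the phenyl on the aromatic nitrogen would stay with compound 3 and compound 4 or move toward the alkyl-bearing compounds.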